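Carbonyl group exchange: compound 3 to compound 4

The source may report more compounds than this note shows. Statements on the series, on what has been measured and on what is new or still open speak of the compounds shown alone.

In a functional assay on PC-3 cells (Homo sapiens), read by MTT assay, with a stated time of 48 h (a lower number here means a stronger inhibitor, a higher number a weaker inhibitor), compound 3 (`CCn1c(C(=O)N(CCC#N)CCC#N)ccc1C(CC)(CC)c1ccc(OCC(O)C(C)(C)C)c(C)c1`) gives 7800 nM and holds the middle place among the three measured compounds. Compound 1 (`CCN(CC)CCCNC(=O)c1ccc(C(CC)(CC)c2ccc(OCC(O)C(C)(C)C)c(C)c2)n1CC`) has the lowest number at 2500 nM while compound 2 (`C#CCNC(=O)c1ccc(C(CC)(CC)c2ccc(OCC(O)C(C)(C)C)c(C)c2)n1CC`) has the highest at 16200 nM in the same read-out.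

Compound 4 (`CCn1c(C(=O)N(C)CC(=O)O)ccc1C(CC)(CC)c1ccc(OCC(O)C(C)(C)C)c(C)c1`) differs from compound 3 by a group of 6 heavy atoms (3 carbon, 1 nitrogen, 2 oxygen; no ring) in place of a group of 9 heavy atoms (6 carbon, 3 nitrogen; no ring), on a carbonyl carbon with (carboxymethyl)(methyl)amino as the entering group.

All three measured steps change this same place and bear on the new one: a 6.5-fold higher number from compound 1 to compound 2 (0.81 log units; beyond the scatter), a 3.1-fold higher number from compound 1 to compound 3 (0.49 log units; beyond the scatter) and a 2.1-fold lower number from compound 2 to compound 3 (0.32 log units; beyond the scatter) are each modest. Among the measured compounds shown here, they give a guide to size more than to direction, as no measured compound carries the entering group. For the measured compounds named here, both groups measured in place of the one in compound 1 gave higher numbers, and that is the only lean available, so a higher number is expected, on thin evidence.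

The expected change in this assay is a 2.3-fold higher number from compound 3 to compound 4 (0.36 log units; beyond the scatter) and thus of the same modest order as the steps among the other compounds. The estimate for compound 4 is 18000 nM with an expected range of 7000 nM to 50000 nM as its likely span.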

Compound 4, half-maximal inhibitory concentration: 23900 nM
Beside the measured number, compound 4's estimate is 1.3-fold (0.12 log units) below it; the range from low to high includes it.
By their numbers in this assay, from the lowest: compound 1; then compound 3; then compounds 2 and 4 (each within the scatter of the next).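

In this assay, among the compounds shown here, putting (carboxymethyl)(methyl)amino on the carbonyl carbon in place of the group of compound 3 gives a 3.1-fold higher number from compound 3 to compound 4 (0.49 log units; beyond the scatter), while the exchange for propargylamino gives a 1.5-fold higher number from compound 2 to compound 4 (0.17 log units; within the scatter), so these two compounds are not separated by this read-out even though the entering group is the first at this place to carry oxygen. The exchange for (3-(diethylamino)propyl)amino gives a 9.6-fold higher number from compound 1 to compound 4 (0.98 log units; beyond the scatter), the widest step yet seen at this place, and all three groups measured in place of that one now give higher numbers, which leaves compound 1 alone at the low end of the series. No measured evidence is available to explain these differences.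

On these data alone, it remains open whether the lower number of compound 1 follows the diethylamino end of its chain or the length of the chain, which (2-(diethylamino)ethyl)amino, a shorter chain with the same amine, or (4-(diethylamino)butyl)amino, a longer one, would help to separate. As far as these compounds go, it is also open how far the free acid of compound 4 matters at this carbonyl carbon, a question that the methyl ester of the carboxymethyl group would address.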